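The source may report more compounds than this note shows. Statements on the series, on what has been measured and on what is new or still open speak of the compounds shown alone.

Compound 1 `CC(C)(C)c1ccc(OC(=O)c2cn(-c3ccccc3)nc2-c2cccnc2)cc1`: > 100000 nM in this cytotoxicity assay
Compound 2 `Cc1ccc(C(C)C)c(OC(=O)c2cn(-c3ccccc3)nc2-c2cccnc2)c1`: 84200 nM

In a functional assay on MCF7 cells (Homo sapiens) for cytotoxicity, read by MTT assay, with a stated time of 48 h (a higher number here means a weaker inhibitor, a lower number a stronger inhibitor), compound 1 reaches only the assay limit of > 100000 nM, which is a limit and not a number. Compound 2 gives 84200 nM in this assay. For the measured compounds named here, that is the only numerical value among the two measured compounds, since the other sits at the limit of > 100000 nM in this assay, at which 1 of the 2 values shown sits. Going by the values given here, the single measured step, an at least 1.1-fold lower number from compound 1 to compound 2 (0.07 log units; that floor lies within the scatter), alters the aryl group on the ester oxygen and leaves the rest of the shared core untouched.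

Compound 3 `Cc1ccc(C(C)C)c(OC(=O)c2cn(-c3ccccc3)nc2-c2ccncc2)c1` differs from compound 2 by pyridin-4-yl in place of pyridin-3-yl on an aromatic carbon. No measured step touches that aromatic carbon, so the measured data give no reason to expect a shift in either direction beyond the scatter of this assay. The step expected in this assay is a 1.1-fold higher number from compound 2 to compound 3 (0.03 log units; within the scatter). Compound 3 is accordingly expected to give about 90000 nM in this assay, with a plausible range from 35000 nM to 250000 nM, and a real chance that only a limit is recorded.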

Compound 3, half-maximal inhibitory concentration: > 100000 nM
Compound 3 was reported as a limit (the forecaster's own chance of this, stated with the estimate: 40%); at least 1.1-fold (0.04 log units) between middle value and limit.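

For the compounds shown here, compound 3 brings the first measured change at this aromatic carbon of the five-membered ring, and pyridin-4-yl in place of pyridin-3-yl gives an at least 1.1-fold higher number from compound 2 to compound 3 (0.07 log units; that floor lies within the scatter). Compound 3 is recorded only as a limit, so this figure is a floor and the full size of the step cannot be read; the values shown in this assay do not separate the two pyridine attachments beyond the scatter. Like compound 1, compound 3 stands at a limit and not at a number, which leaves compound 2 as the only compound with a numerical value in this assay: the limit of > 100000 nM in this assay, at which 2 of the 3 values shown sit.

As far as these compounds go, whether any group at this aromatic carbon can bring a clear shift in this assay remains open, for example pyridin-2-yl, a plain phenyl, or a pyridine ring carrying an amine or a carboxylic acid. Also open, from the compounds shown here alone, is how the 2-isopropyl-5-methylphenyl ester would respond to a longer chain on its aryl ring, or whether pyridin-4-yl would give a number alongside another aryl group on the ester oxygen.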